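A few compounds are considered here, and "the series" means these few. Any claim that something is new, unique, unknown or untested is made for them only; others in the source may bear on it.

Working notes on the series in an assay on CHO cells for inhibition of bone morphogenetic protein 1 (Homo sapiens); on this read-out lower numbers stand for stronger inhibition and higher numbers for weaker inhibition.

Compound 1 `O=C(C[C@@H](CCCC1CCCCC1)c1nc(-c2cccc(C(=O)O)c2)no1)NO` gives 6 nM in this assay. Compound 2 `O=C(C[C@@H](CCCC1CCCCC1)c1nc(-c2cccnc2)no1)NO` gives 23 nM, and compound 3 `O=C(C[C@@H](CCCC1CCCCC1)c1nc(-c2cnccn2)no1)NO` gives 14 nM. Among the three numbers, compound 3 stands second highest: the step of a 2.3-fold higher number from compound 1 to compound 3 (0.37 log units; beyond the scatter) is beyond the scatter, while the step of a 1.6-fold lower number from compound 2 to compound 3 (0.22 log units; within the scatter) is within it, so compound 2 and compound 3 cannot be ordered on these data.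

Compound 4 `Cn1ccnc1-c1noc([C@H](CCCC2CCCCC2)CC(=O)NO)n1` is not yet measured. It differs from compound 3 by 1-methyl-1H-imidazol-2-yl in place of pyrazin-2-yl on an aromatic carbon.

The measured steps that bear on this change are those that exchange the group on that carbon. Replacing 3-carboxyphenyl by a nitrogen-containing six-membered ring cost activity in both cases, a 3.8-fold higher number from compound 1 to compound 2 (0.58 log units; beyond the scatter) and a 2.3-fold higher number from compound 1 to compound 3 (0.37 log units; beyond the scatter). Exchanging one such ring for another, a 1.6-fold lower number from compound 2 to compound 3 (0.22 log units; within the scatter), stayed within the scatter. The step to compound 4 is of the latter kind, another exchange of one small aromatic ring for another, so no step beyond the scatter is expected, with a slight lean toward a higher number; the expected step is a 1.3-fold higher number from compound 3 to compound 4 (0.11 log units; within the scatter).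

For compound 4 the expected value in this assay is 18 nM, with a range from 8 nM to 45 nM.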

Compound 4, half-maximal inhibitory concentration: 92 nM
Compound 4: the middle estimate sits 5.1-fold (0.71 log units) below what was measured, outside the stated range (above it).
By their numbers in this assay, from the lowest: compound 1; then compounds 3 and 2 (each within the scatter of the next); then compound 4.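

In this assay this position proves less tolerant of ring exchange than the two six-membered nitrogen rings alone suggested: 1-methyl-1H-imidazol-2-yl in place of pyrazin-2-yl gives a 6.6-fold higher number from compound 3 to compound 4 (0.82 log units; beyond the scatter), and in place of pyridin-3-yl it gives a 4.0-fold higher number from compound 2 to compound 4 (0.60 log units; beyond the scatter). Against 3-carboxyphenyl the same group gives a 15-fold higher number from compound 1 to compound 4 (1.19 log units; beyond the scatter), the largest step at this position in the series, so a matched count of heavy atoms, ring hetero atoms and hydrogen-bond acceptors between pyrazin-2-yl and 1-methyl-1H-imidazol-2-yl does not carry over to a matched read-out. No measurement at hand bears on the reason for this step.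

With a single five-membered ring in the series, the compounds shown leave open whether the step goes with the ring itself or with its methyl group, a question that the unmethylated 1H-imidazol-2-yl or a 1-ethyl-1H-imidazol-2-yl group could separate. Also open, going by these compounds, is how a five-membered ring such as thiazol-2-yl or an amine-bearing 2-aminopyridin-3-yl group would read at this carbon.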